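The compounds below may be only part of what the source reports. "The series", "measured", "known", "first", "only" and "open" are said of these compounds alone.

Measured in a functional assay on A549 cells (Homo sapiens) for cytotoxicity, read by MTT assay, with a stated time of 68 h; on this read-out lower numbers stand for stronger inhibition and higher numbers for weaker inhibition:
- compound 1 `O=C(Nc1cccc(-c2cccc(F)c2)c1)C(Cl)Cl`: 9530 nM
- compound 2 `O=C(Nc1cccc(-c2cccc(C(F)(F)F)c2)c1)C(Cl)Cl`: 18500 nM
- compound 3 `O=C(Nc1cccc(-c2cccc(Cl)c2)c1)C(Cl)Cl`: 21400 nM

In this assay, compound 3 gives 21400 nM. It lies within the scatter of compound 2, with a 1.2-fold higher number from compound 2 to compound 3 (0.06 log units; within the scatter), but apart from compound 1, with a 2.2-fold higher number from compound 1 to compound 3 (0.35 log units; beyond the scatter).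

The next structure is compound 4 `O=C(Nc1cccc(-c2ccccc2)c1)C(Cl)Cl`, and the change is hydrogen in place of chloro on an aromatic carbon, meta to a large group. Going by the values given here, no measured compound carries hydrogen there, so the nearest evidence comes from the swaps among the three measured substituents. Among the compounds with values here, these are small, with a 1.9-fold higher number from compound 1 to compound 2 (0.29 log units; within the scatter) alongside the two steps above, and only the step to compound 3 from compound 1 passes the scatter. They give no clear direction for removing the chloro. A small step is therefore expected in this assay, probably none beyond the scatter.

The expected change is a 1.3-fold lower number from compound 3 to compound 4 (0.13 log units; within the scatter). For compound 4 the estimated value is 16000 nM, with an expected range of 8000 nM to 32000 nM.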

Compound 4, half-maximal inhibitory concentration: 8900 nM
Beside the measured number, compound 4's estimate is 1.8-fold (0.25 log units) above it, and the stated range covers the measured number.
By their numbers in this assay, from the lowest: compounds 4, 1, 2 and 3 (each within the scatter of the next, the first and the last beyond it).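

With hydrogen on this aromatic carbon in this assay, the number falls both with a 2.4-fold lower number from compound 3 to compound 4 (0.38 log units; beyond the scatter) and with a 2.1-fold lower number from compound 2 to compound 4 (0.32 log units; beyond the scatter), so neither chloro nor trifluoromethyl is needed here for the effect on these cells, and removing either gives the clear direction the earlier swaps lacked. Fluoro stands apart from those two groups, as a 1.1-fold lower number from compound 1 to compound 4 (0.03 log units; within the scatter) leaves it indistinguishable from hydrogen at this position, although compound 1 also lies within the scatter of compound 2. Nothing available explains these steps.

As far as these compounds go, it remains open whether an amine, a carboxylic acid or a longer chain at this position would take the number outside the band spanned by these four compounds. The compounds shown also leave open whether the same order holds elsewhere on the shared core.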